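The source may report more compounds than this note shows. Statements on the series, on what has been measured and on what is new or still open speak of the compounds shown alone.

Measured compounds:
compound 1 `O=c1[nH]cc(S(=O)(=O)Nc2ccccc2-c2cn(-c3ccc(F)cc3)nn2)c(=O)[nH]1` — 6390 nM
compound 2 `O=c1[nH]cc(S(=O)(=O)Nc2ccccc2-c2cn(-c3ccccc3Cl)nn2)c(=O)[nH]1` — 2740 nM
compound 3 `O=c1[nH]cc(S(=O)(=O)Nc2ccc(-c3cn(-c4ccc(F)cc4)nn3)cc2)c(=O)[nH]1` — 9720 nM

Of the compounds shown here, three have been tested in a functional assay on A549 cells (Homo sapiens) for antiproliferative activity, read by MTT assay, with a stated time of 24 h; a lower number here means a stronger inhibitor, a higher number a weaker inhibitor. Compound 1 and compound 2 share one core and differ in a single place: 2-chlorophenyl in place of 4-fluorophenyl on an aromatic nitrogen That change gave a 2.3-fold lower number from compound 1 to compound 2 (0.37 log units; beyond the scatter), a modest but real gain. Compound 3 is built from the same atoms as compound 1 joined differently; the difference between the two cores is not broken down here. In this assay compound 3 gives 9720 nM, which sits within the scatter of compound 1, while compound 2 lies beyond the scatter from it.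

Compound 4 `O=c1[nH]cc(S(=O)(=O)Nc2ccc(-c3cn(-c4ccccc4Cl)nn3)cc2)c(=O)[nH]1` has not yet been measured. It stands to compound 3 as compound 2 stands to compound 1: 2-chlorophenyl in place of 4-fluorophenyl on an aromatic nitrogen The place lines of the two changes read the same word for word, so this is the same change on a different core. The expectation rests on the step from compound 1 to compound 2, a 2.3-fold lower number from compound 1 to compound 2 (0.37 log units; beyond the scatter), transferred to compound 3 with added uncertainty because the core of compound 3 is not the core of compound 1. Compound 4 is therefore expected to show a step of a 2.2-fold lower number from compound 3 to compound 4 (0.33 log units; beyond the scatter) relative to compound 3. On that basis compound 4 is estimated at 4500 nM in this assay, with a range from 2300 nM to 9500 nM.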

Compound 4, half-maximal inhibitory concentration: 2810 nM
Estimate against measurement, compound 4: 1.6-fold (0.20 log units) above; measured number inside the range.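

In this assay, putting 2-chlorophenyl in place of 4-fluorophenyl on the aromatic nitrogen gave a 3.5-fold lower number from compound 3 to compound 4 (0.54 log units; beyond the scatter), and this step can be set beside the earlier one: the same change on two cores in this assay, a 2.3-fold lower number (0.37 log units; beyond the scatter) from compound 1 to compound 2 and a 3.5-fold lower number (0.54 log units; beyond the scatter) from compound 3 to compound 4, 1.5-fold (0.17 log units) apart, within the scatter of two such steps The change therefore carried over between these two cores in the same direction, and its size on one core cannot be told apart from its size on the other. This does not show that the step would hold on any further core, and it does not separate the effect of exchanging the halogen from the effect of moving it, since the two groups differ in both respects.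

The compounds shown leave open how 2-fluorophenyl or 4-chlorophenyl would compare on either core, which would separate those two differences. They also leave open how an unsubstituted phenyl, or a phenyl carrying an amine or a carboxylic acid, would stand on the same aromatic nitrogen.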